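Methoxy on the benzyl group of compound 3

The source may report more compounds than this note shows. Statements on the series, on what has been measured and on what is new or still open speak of the compounds shown alone.

The series shares the core of compound 1 `COc1ccc(-n2c(S)nnc2-c2cc(OC)c(OC)c(OC)c2)cc1` and varies at the sulfur. In a functional assay on PC-3 cells (Homo sapiens) for inhibition, read by MTT assay, with a stated time of 48 h (on this read-out lower numbers stand for stronger inhibition and higher numbers for weaker inhibition), compound 1 gives > 60000 nM, which is a limit of the assay and not a number. Compound 2 `COc1ccc(-n2c(SC)nnc2-c2cc(OC)c(OC)c(OC)c2)cc1` gives > 60000 nM, again a limit. Going by the values given here, compound 3 `COc1ccc(-n2c(SCc3ccccc3)nnc2-c2cc(OC)c(OC)c(OC)c2)cc1` gives 34100 nM, the only actual number so far.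

Compound 4 `COc1ccc(CSc2nnc(-c3cc(OC)c(OC)c(OC)c3)n2-c2ccc(OC)cc2)cc1` differs from compound 3 in one place: methoxy in place of hydrogen on an aromatic carbon. Methoxy stands in place of hydrogen on an aromatic carbon, para to a large group, so that benzyl becomes 4-methoxybenzyl.

Two measured steps end at compound 3: an at least 1.7-fold lower number from compound 1 to compound 3 (0.24 log units; that floor lies within the scatter) and an at least 1.7-fold lower number from compound 2 to compound 3 (0.24 log units; that floor lies within the scatter). Both floors lie within the scatter. The third, a step that the two limits leave unreadable from compound 1 to compound 2, gives no size. Among the compounds with values here, no measured compound carries a group on the phenyl of the benzyl, so the series offers no direct precedent for this change. No step beyond the scatter is therefore expected in this assay, and no direction is favoured. The estimate stays anchored on compound 3 at 34100 nM.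

The expected step is a 1.1-fold lower number from compound 3 to compound 4 (0.03 log units; within the scatter), within the scatter.

For compound 4 the estimated value is 32000 nM, with an expected range from 14000 nM to 60000 nM.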

Compound 4, half-maximal inhibitory concentration: 40300 nM
Compound 4: middle estimate off by 1.3-fold (0.10 log units), on the low side, and the stated range covers the measured number.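

In this assay, going by these compounds alone, methoxy on the benzyl group gives a 1.2-fold higher number from compound 3 to compound 4 (0.07 log units; within the scatter), the first reading of a substituent on that phenyl ring, and the two values cannot be told apart. At this place on the ring, benzyl and 4-methoxybenzyl therefore read as equivalent, and the series still has only weak, near-limit activity. Against the smaller sulfur substituents the new group gives an at least 1.4-fold lower number from compound 2 to compound 4 (0.17 log units; that floor lies within the scatter) and an at least 1.4-fold lower number from compound 1 to compound 4 (0.17 log units; that floor lies within the scatter), so the 4-methoxybenzyl group, like benzyl, shows no separation beyond the scatter, and the size of either step stays hidden because both rest on a limit: the limit of > 60000 nM in this assay, at which 2 of the 4 values shown sit.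

As far as these compounds go, whether any group on this aromatic carbon can move the value beyond the scatter remains open, for example a primary amine, a carboxylic acid or a nitrile in place of methoxy. Also open, from the compounds shown here alone, is whether a longer chain between the sulfur and the phenyl, such as 2-phenylethyl, would give a step that can be told from benzyl.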